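Swapping one bicyclic group for another at the amide-type nitrogen

The compounds below may be only part of what the source reports. "The series", "measured", "known", "first", "only" and "open" are said of these compounds alone.

Measured so far:
compound 1 `CC(C(=O)NCc1ccc(C(F)(F)F)cc1N1CCC(Cc2ccccc2)(N(C)C)CC1)c1ccc(NS(C)(=O)=O)c(F)c1` — 8.2 nM
compound 2 `CN(C)C1(Cc2ccccc2)CCN(c2cc(C(F)(F)F)ccc2CNC(=O)Nc2ccc3c(c2)OCC3)CC1` — 31.3 nM
compound 3 `CN(C)C1(Cc2ccccc2)CCN(c2cc(C(F)(F)F)ccc2CNC(=O)Nc2cccc3[nH]c(=O)ccc23)CC1` — 30.6 nM

In an assay on CHO cells for antagonist activity at transient receptor potential cation channel subfamily V member 1 (Homo sapiens), read by scintillation counting, with a stated time of 5 min, in the presence of a further agent that is not named here (on this read-out higher numbers stand for an effect only at larger amounts of compound and lower numbers for an effect already at smaller amounts), compound 3 gives 30.6 nM. Among the three measured compounds, compound 3 and compound 2 give numbers within the scatter of each other, while compound 1 gives a lower number than compound 3, beyond the scatter.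

Compound 4 `CN(C)C1(Cc2ccccc2)CCN(c2cc(C(F)(F)F)ccc2CNC(=O)Nc2ccc3cnccc3c2)CC1` differs from compound 3 by a group of 10 heavy atoms (9 carbon, 1 nitrogen; one six-membered aromatic ring of carbon only, one six-membered aromatic ring with 1 hetero atom) in place of a group of 11 heavy atoms (9 carbon, 1 nitrogen, 1 oxygen; one six-membered aromatic ring of carbon only, one six-membered aromatic ring with 1 hetero atom), on an amide-type nitrogen. Among the compounds with values here, the one measured step that bears on this place is the change a 1.0-fold lower number from compound 2 to compound 3 (0.01 log units; within the scatter): replacing one bicyclic group on the amide-type nitrogen with another left the number where it was. On that basis, compound 4 is expected to show no step beyond the scatter in this assay, an estimated change of a 1.0-fold lower number from compound 3 to compound 4 (0.01 log units; within the scatter). Compound 4 is therefore estimated at 30 nM, within a range from 12 nM to 75 nM.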

Compound 4, half-maximal effective concentration: 156 nM
Compound 4: the middle estimate sits 5.2-fold (0.72 log units) below what was measured, outside the stated range (above it).
By their numbers in this assay, from the lowest: compound 1; then compounds 3 and 2 (each within the scatter of the next); then compound 4.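

In this assay, the bicyclic group on this amide-type nitrogen can matter: isoquinolin-6-yl brings a 5.1-fold higher number from compound 3 to compound 4 (0.71 log units; beyond the scatter) and a 5.0-fold higher number from compound 2 to compound 4 (0.70 log units; beyond the scatter), while the earlier swap stayed within the scatter. So two different bicyclic groups giving matching numbers did not mean that any such group would do. Nothing measured here accounts for this rise.

Going by these compounds, it remains open whether the ring nitrogen itself matters, as a naphthalen-2-yl group, with carbon only in both rings, could show. A quinolin-6-yl group could likewise show whether the nitrogen's place in the ring matters.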